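Moving the nitro group: a step at the assay limit

A few compounds are considered here, and "the series" means these few. Any claim that something is new, unique, unknown or untested is made for them only; others in the source may bear on it.

In an ADME assay on L132 cells (Homo sapiens) for cytotoxicity, read by MTT assay, with a stated time of 48 h (a lower number here means a stronger inhibitor, a higher number a weaker inhibitor), compound 1 (`C/C(=C\CC/C(C)=C/CC[C@@H]1[C@@]2(C)CCC(=O)C(C)(C)[C@H]2CC[C@@]1(C)O)CC/C=C(\C)C(=O)OCc1cn(-c2ccc(F)cc2)nn1`) stands only at a limit (> 150000 nM). Compound 2 (`C/C(=C\CC/C(C)=C/CC[C@@H]1[C@@]2(C)CCC(=O)C(C)(C)[C@H]2CC[C@@]1(C)O)CC/C=C(\C)C(=O)OCc1cn(-c2ccc([N+](=O)[O-])cc2)nn1`) also stands only at a limit (> 150000 nM), so its position offers no number. The change to compound 3 (`C/C(=C\CC/C(C)=C/CC[C@@H]1[C@@]2(C)CCC(=O)C(C)(C)[C@H]2CC[C@@]1(C)O)CC/C=C(\C)C(=O)OCc1cn(-c2ccccc2[N+](=O)[O-])nn1`) is 2-nitrophenyl in place of 4-nitrophenyl on an aromatic nitrogen. Among the compounds with values here, the one measured step (a step that the two limits leave unreadable from compound 1 to compound 2) has no readable size, and both values sit at the same limit (the limit of > 150000 nM in this assay, at which 2 of the 2 values shown sit). The expected step (a number no higher from compound 2 to compound 3 (the limit leaves the size open)) is therefore none beyond the scatter in this assay, in either direction. Compound 3 is estimated at 150000 nM, with an expected range of 80000 nM to 300000 nM, and will probably read as a limit again.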

Compound 3, half-maximal inhibitory concentration: > 150000 nM
Compound 3: only a limit was reported (the forecaster's own chance of this, stated with the estimate: 85%); the middle value lies on the limit itself.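

In this assay compound 3 gives > 150000 nM, a limit and not a number. No step among compound 1, compound 2 and compound 3 can be read: the limit of > 150000 nM in this assay, at which 3 of the 3 values shown sit.

The compounds shown leave open whether 4-fluorophenyl, 4-nitrophenyl and 2-nitrophenyl differ at all in this cytotoxicity read-out.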